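Chloro for methyl, carried from one pair to the next

This account rests on a few compounds, and the source may have more. Where it says the series, first, only, none or still open, it means among the compounds named here.

Measured compounds:
compound 1 `CSc1ccc(N(C)c2nc(C)nc3ccccc23)cc1` gives 1.6 nM
compound 2 `COc1cccc2cc(N(C)c3nc(C)nc4ccccc34)ccc12` gives 2.9 nM
compound 3 `CSc1ccc(N(C)c2nc(Cl)nc3ccccc23)cc1` gives 3.3 nM

All three numbers come from a functional assay on SK-OV-3 cells (Homo sapiens) for cytotoxicity, read by sulforhodamine B assay; a lower number here means a stronger inhibitor, a higher number a weaker inhibitor. In this assay compound 1 gives 1.6 nM and compound 3 gives 3.3 nM; the change between them, (chloro in place of methyl on an aromatic carbon), made a 2.1-fold higher number from compound 1 to compound 3 (0.31 log units; beyond the scatter). Compound 2 gives 2.9 nM, which lies within the scatter of compound 3 and also within the scatter of compound 1. The difference between the core of compound 2 and the core of compound 1 is not broken down here.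

Compound 4 `COc1cccc2cc(N(C)c3nc(Cl)nc4ccccc34)ccc12` has not been measured in this assay. It differs from compound 2 by chloro in place of methyl on an aromatic carbon, the same change as from compound 1 to compound 3, at a place described in the same words. Since compound 2 gives 2.9 nM, compound 4 is expected to come out near 6 nM, in a range of 3 nM to 13 nM. The expected step is a 2.1-fold higher number from compound 2 to compound 4 (0.32 log units; beyond the scatter), taken from the single shown instance, a 2.1-fold higher number from compound 1 to compound 3 (0.31 log units; beyond the scatter); one prior case is a thin basis, so the range is kept wide.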

Compound 4, half-maximal inhibitory concentration: 2.8 nM
For compound 4 the middle estimate is 2.1-fold (0.33 log units) above the measured one, and the stated range ends above it.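

In this assay chloro in place of methyl on an aromatic carbon gives a 1.0-fold lower number from compound 2 to compound 4 (0.02 log units; within the scatter), while the same change on the other core gives a 2.1-fold higher number from compound 1 to compound 3 (0.31 log units; beyond the scatter). Although only the first of these steps lies beyond the scatter, the two steps cannot be told apart: the same change on two cores in this assay, a 2.1-fold higher number (0.31 log units; beyond the scatter) from compound 1 to compound 3 and a 1.0-fold lower number (0.02 log units; within the scatter) from compound 2 to compound 4, 2.1-fold (0.33 log units) apart, within the scatter of two such steps. The step seen on one core therefore gives no firm reading of its size on the other, but with a single pair per core this shows neither that the two cores respond differently to the change nor that they respond alike.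

On these data alone, what an amine, a methoxy or a longer chain would give at this place, on the aromatic carbon between two ring nitrogen atoms, stays open. Going by these compounds alone, also open is whether a third core carrying the same two groups would follow the step seen with compound 1 and compound 3 or the one seen with compound 2 and compound 4.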